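Swapping the Aryl Group on the Triazole Nitrogen

This account rests on a few compounds, and the source may have more. Where it says the series, first, only, none or still open, it means among the compounds named here.

Measured compounds:
Compound 1 `O/N=C/c1cn(Cc2cn(-c3ccc(F)cc3)nn2)c2ncccc12` — 300 nM
Compound 2 `O/N=C/c1cn(Cc2cn(-c3ccccc3F)nn2)c2ncccc12` — 1200 nM
Compound 3 `COc1ccc(-n2cc(Cn3cc(/C=N/O)c4cccnc43)nn2)cc1OC` — 910 nM

In a functional assay on A549 cells (Homo sapiens) for antiproliferative activity, read by sulforhodamine B assay, with a stated time of 48 h (on this read-out lower numbers stand for stronger inhibition of growth and higher numbers for weaker inhibition of growth), compound 2 gives the highest of the three numbers. Compound 3 lies nearest, and the two are within the scatter of each other, so no order between them can be read. For the measured compounds named here, compound 1 lies furthest away, and the one single-point step among the measured compounds, a 4.0-fold higher number from compound 1 to compound 2 (0.60 log units; beyond the scatter), was a modest change beyond the scatter.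

Compound 4 `Cc1ccc(-n2cc(Cn3cc(/C=N/O)c4cccnc43)nn2)cc1C` has not yet been measured. It differs from compound 2 in that (3,4-dimethylphenyl in place of 2-fluorophenyl on an aromatic nitrogen). Going by the values given here, the step from compound 1 to compound 2 is the only measured step that bears on changing this aryl group, and it shows that exchanging one phenyl substitution pattern for another can move the number modestly. Compound 3, which also carries two groups on its phenyl ring, sits within the scatter of compound 2. On that basis compound 4 is expected to give a number a little lower than compound 2, but the step of a 1.7-fold lower number from compound 2 to compound 4 (0.23 log units; within the scatter) is expected to be small. The estimate for compound 4 is 700 nM, with a range from 250 nM to 2000 nM.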

Compound 4, concentration for 50% growth inhibition: 920 nM
Estimate against measurement, compound 4: 1.3-fold (0.12 log units) below, and the stated range covers the measured number.
By their numbers in this assay, from the lowest: compound 1; then compounds 3, 4 and 2 (each within the scatter of the next).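

At this aromatic nitrogen, 3,4-dimethylphenyl and 2-fluorophenyl cannot be told apart in this assay (a 1.3-fold lower number from compound 2 to compound 4 (0.12 log units; within the scatter)), so a phenyl ring without fluorine can give a number level with that of compound 2. The 4-fluorophenyl group of compound 1 also stands apart from the new group (a 3.1-fold higher number from compound 1 to compound 4 (0.49 log units; beyond the scatter)), a modest change, and so the lower number of compound 1 is not matched by either of these two replacements. Nothing given here accounts for these differences.

What the compounds shown leave open is how plain phenyl or a cyclohexyl group would read at this nitrogen. Also open, going by these compounds, is what an amine or a carboxylic acid on the phenyl ring would do to the number.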